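This account rests on a few compounds, and the source may have more. Where it says the series, first, only, none or still open, it means among the compounds named here.

Measured so far in a functional assay for inhibition of B1 bradykinin receptor (Homo sapiens), read by calcium flux; a lower number here means a stronger inhibitor, a higher number a weaker inhibitor:
compound 1 `CCCCOc1ccc(S(=O)(=O)N2CCCC[C@H]2CC(=O)N[C@@H]2CCCc3cc(CNC(C)(C)C)ccc32)cc1` gives 590 nM
compound 2 `CC(C)(C)NCc1ccc2c(c1)CCC[C@H]2NC(=O)C[C@@H]1CCCCN1S(=O)(=O)c1ccc(Cl)cc1` gives 810 nM

Of these two numbers, compound 2 shows the higher one in this assay, but the gap to compound 1 is within the scatter, so the two compounds cannot be told apart. Among the measured compounds shown here, the single measured step, a 1.4-fold higher number from compound 1 to compound 2 (0.14 log units; within the scatter), swaps the substituent on the aryl ring that sits on the sulfonyl sulfur and stayed within the scatter. Compound 3 `Cc1ccc(S(=O)(=O)N2CCCC[C@H]2CC(=O)N[C@@H]2CCCc3cc(CNC(C)(C)C)ccc32)cc1C(F)(F)F` has not been measured yet; it alters the same part of the shared core: 4-methyl-3-(trifluoromethyl)phenyl in place of 4-chlorophenyl on a sulfonyl sulfur. For the measured compounds named here, because the only comparable step, a 1.4-fold higher number from compound 1 to compound 2 (0.14 log units; within the scatter), made no difference beyond the scatter, no step beyond the scatter is expected here either, in neither direction. Compound 3 is therefore estimated at 800 nM, with a range from 350 nM to 1900 nM, which means an expected step of a 1.0-fold lower number from compound 2 to compound 3 (0.01 log units; within the scatter).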

Compound 3, half-maximal inhibitory concentration: 16 nM
The estimate for compound 3 lay 50-fold (1.70 log units) above the measured number; the whole stated range lies above it.
By their numbers in this assay, from the lowest: compound 3; then compounds 1 and 2 (each within the scatter of the next).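

In this assay, among the compounds shown here, the 4-methyl-3-(trifluoromethyl)phenyl group brings a 51-fold lower number from compound 2 to compound 3 (1.70 log units; beyond the scatter) when it replaces 4-chlorophenyl and a 37-fold lower number from compound 1 to compound 3 (1.57 log units; beyond the scatter) when it replaces 4-butoxyphenyl, so the aryl group on the sulfonyl sulfur can matter greatly, although the one earlier swap at this position stayed within the scatter. Compound 3 is the strongest inhibitor of the three, since its steps to both others lie beyond the scatter. Nothing available here accounts for this large drop in the number.

The compounds shown cannot separate the methyl from the trifluoromethyl, so it stays open whether one of them or the two together carry the gain. On these data alone, how a nitrile or a carboxylic acid on the same aryl ring would read also remains open.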